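The compounds below may be only part of what the source reports. "The series", "measured", "known", "first", "only" and "open" are said of these compounds alone.

Working notes on the cinnamoyl boron series, cytotoxicity arm.

Compound 1 `O=C(/C=C/c1ccc2c(c1)B(O)OC2)c1cccnc1` carries pyridin-3-yl on the carbonyl carbon of the shared core. In a toxicity assay on MCF-10A cells (Homo sapiens) for cytotoxicity, read by MTT assay, with a stated time of 48 h (on this read-out higher numbers stand for weaker inhibition and lower numbers for stronger inhibition), compound 1 gives 34400 nM, the highest of the two numbers reported so far. Compound 3 `CSc1ccc(C(=O)/C=C/c2ccc3c(c2)B(O)OC3)cc1` gives 7400 nM in this assay, a lower number than compound 1 and beyond the scatter. Compound 2 `Cn1cccc1C(=O)/C=C/c1ccc2c(c1)B(O)OC2` in this assay reaches only the limit > 100000 nM, not a number, which is the limit of > 100000 nM in this assay, at which 1 of the 3 values shown sits. For the measured compounds named here, the one measured step away from compound 1 is an at least 2.9-fold higher number from compound 1 to compound 2 (0.46 log units; beyond the scatter).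

Compound 4 `O=C(/C=C/c1ccc2c(c1)B(O)OC2)c1cccc(F)c1` differs from compound 1 by 3-fluorophenyl in place of pyridin-3-yl on a carbonyl carbon. Going by the values given here, no measured step matches this change. Among the compounds with values here, the only step from compound 1 exchanges its aromatic ring for another one with a hetero atom and moves to a higher number; compound 3, whose ring on the carbonyl carbon is also carbon only, sits at a lower number than compound 1. On this basis a modest step toward a lower number in this assay is expected for compound 4, with wide uncertainty. Compound 4 is therefore estimated at 15000 nM in this assay, in the range 5000 nM to 50000 nM. The estimated step is a 2.3-fold lower number from compound 1 to compound 4 (0.36 log units; beyond the scatter).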

Compound 4, half-maximal inhibitory concentration: 15800 nM
The estimate for compound 4 lay 1.1-fold (0.02 log units) below the measured number; low and high end bracket the measured number.
By their numbers in this assay, from the lowest: compound 3; then compound 4; then compound 1. At a limit, above all of these: compound 2.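

In this assay, the carbonyl carbon now shows a measured step in the downward direction, with 3-fluorophenyl in place of pyridin-3-yl giving a 2.2-fold lower number from compound 1 to compound 4 (0.34 log units; beyond the scatter), whereas the earlier step from compound 1 ran upward. Setting 3-fluorophenyl in place of 1-methyl-1H-pyrrol-2-yl gives an at least 6.3-fold lower number from compound 2 to compound 4 (0.80 log units; beyond the scatter), so this one position now spans a wider range than the earlier step showed, and among the four compounds the two with a ring of carbon only on the carbonyl carbon, compound 3 and compound 4, both carry lower numbers than compound 1 and compound 2, with none of the four going against this. The entry for compound 2 is a limit and not a number: the limit of > 100000 nM in this assay, at which 1 of the 4 values shown sits.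

The compounds shown leave open whether the step to compound 4 follows from the loss of the ring nitrogen or from the entry of fluorine, a question that an unsubstituted phenyl on the carbonyl carbon would separate. They also leave open how this position responds to a phenyl ring bearing an amine or a carboxylic acid.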